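The source may hold more compounds than are shown below. What is called first, only, known or untested is meant among the compounds shown, and "the series" means these compounds.

Measured in a functional assay on MCF7 cells (Homo sapiens) for antiproliferative activity, read by CellTiter-Glo, with a stated time of 5 days; on this read-out higher numbers stand for weaker inhibition and lower numbers for stronger inhibition:

- Compound 1 `CC/C(=C(/c1ccc(/C=C/C(=O)O)cc1)c1ccc2nccn2c1)c1ccccc1`: 170 nM
- Compound 2 `CC/C(=C(/c1ccc(/C=C/C(=O)O)cc1)c1ccc2cncn2c1)c1ccccc1`: > 500 nM (a limit, not a number)
- Compound 3 `CC/C(=C(/c1ccc(/C=C/C(=O)O)cc1)c1ccn2nncc2c1)c1ccccc1`: > 500 nM (a limit, not a number)

Compound 3 has no exact value and stands at the limit of > 500 nM in this assay, at which 2 of the 3 values shown sit. Compound 4 `CC/C(=C(/c1ccc(/C=C/C(=O)O)cc1)c1ccc2nncn2c1)c1ccccc1` has the same atoms as compound 3, joined differently: a group of 9 heavy atoms (6 carbon, 3 nitrogen; one five-membered aromatic ring with 3 hetero atoms, one six-membered aromatic ring with 1 hetero atom) in place of a group of 9 heavy atoms (6 carbon, 3 nitrogen; one five-membered aromatic ring with 3 hetero atoms, one six-membered aromatic ring with 1 hetero atom), on a double-bonded chain carbon bound to an aromatic carbon and a double-bonded chain carbon.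

For the measured compounds named here, two measured steps bear on this change: an at least 2.9-fold higher number from compound 1 to compound 2 (0.46 log units; beyond the scatter), and an at least 2.9-fold higher number from compound 1 to compound 3 (0.46 log units; beyond the scatter). They show that exchanging one such group for another of the same size on this carbon can shift the result in this assay. The remaining comparison gives no size: a step that the two limits leave unreadable from compound 2 to compound 3. Only compound 1 has an exact value, so the measurements give no firm size for a step that starts from a limit. A modest move toward a lower number is the most that can be expected, and a result at the limit would be no surprise. The expected change is an at least 1.2-fold lower number from compound 3 to compound 4 (0.09 log units; that floor lies within the scatter). For compound 4, the estimated value is 400 nM, with an expected range of 150 nM to 1000 nM.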

Compound 4, half-maximal inhibitory concentration: > 500 nM
Compound 4 gave a limit, no number; the forecaster's own chance of this, stated with the estimate: 50%; at least 1.2-fold (0.09 log units) between middle value and limit.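

A third exchange of one same-sized group for another on this double-bonded chain carbon ends in weaker inhibition in this assay, with an at least 2.9-fold higher number from compound 1 to compound 4 (0.46 log units; beyond the scatter). Compound 4 also gives only a limit, so compound 1 remains the only one of the four with an exact value, and rearranging the same atoms from compound 3 to compound 4 yields no readable gain. The steps among compound 2, compound 3 and compound 4 cannot be read, and the results now gather at a single limit: the limit of > 500 nM in this assay, at which 3 of the 4 values shown sit.

As far as these compounds go, how far beyond that limit these three compounds lie remains open, and so does their order among themselves. From the compounds shown here alone, it is also open whether adding a methyl group or an amine to the group in compound 1 would keep its activity.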